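A chloro substituent on the methyl imide scaffold

The source may report more compounds than this note shows. Statements on the series, on what has been measured and on what is new or still open speak of the compounds shown alone.

Measured so far:
compound 1, `O=C1C2ON=C(c3cn(-c4ccccc4)nc3-c3ccccc3)C2C(=O)N1c1ccccc1`, 47.4%
compound 2, `CN1C(=O)C2ON=C(c3cn(-c4ccccc4)nc3-c3ccccc3)C2C1=O`, 30.6%
compound 3, `O=C1C2ON=C(c3cn(-c4ccccc4)nc3-c3ccc(Cl)cc3)C2C(=O)N1c1ccccc1`, 43.2%

All three were tested in a functional assay on the whole organism (Abdomen, strain Swiss albino) with Mus musculus as the target, with stated times of 10 min and 5 min, at a dose of 30 mg/kg by the oral route; on this read-out higher numbers stand for a stronger effect at the one dose given and lower numbers for a weaker effect. Compound 2 stands lowest of the three values; compound 3 is its nearest neighbour, and compound 1 lies furthest from it. The step of a number 16.8 percentage points lower from compound 1 to compound 2 (beyond the scatter) shows that the methyl in place of phenyl on the amide-type nitrogen in the ring costs a modest but real amount of activity. The step of a number 4.2 percentage points lower from compound 1 to compound 3 (within the scatter), chloro in place of hydrogen on an aromatic carbon, stays within the scatter.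

Compound 4, `CN1C(=O)C2ON=C(c3cn(-c4ccccc4)nc3-c3ccc(Cl)cc3)C2C1=O`, has not yet been measured in this assay. It differs from compound 2 by chloro in place of hydrogen on an aromatic carbon. Among the compounds with values here, the only measured step that bears on this change is a number 4.2 percentage points lower from compound 1 to compound 3 (within the scatter), the same exchange made on the phenyl imide rather than on the methyl imide, and it produced no shift beyond the scatter. On that basis the step of a number 3.6 percentage points lower from compound 2 to compound 4 (within the scatter) is expected to be small, at most a slight drop, and nothing beyond the scatter.

Compound 4 is therefore estimated at 27%, with a range from 15% to 40%.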

Compound 4, a percentage reported as activity, at one dose (the size of the read-out at that dose, not a potency): 23.2%
For compound 4 the middle estimate is 3.8 percentage points above the measured one; the range from low to high includes it.
By their numbers in this assay, from the lowest: compounds 4 and 2 (each within the scatter of the next); then compounds 3 and 1 (each within the scatter of the next).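

In this assay, chloro in place of hydrogen on the aromatic carbon has now been read on the methyl imide as well as the phenyl imide, giving a number 7.4 percentage points lower from compound 2 to compound 4 (within the scatter), so this exchange stays within the scatter on both scaffolds: the same change on two cores in this assay, a number 4.2 percentage points lower (within the scatter) from compound 1 to compound 3 and a number 7.4 percentage points lower (within the scatter) from compound 2 to compound 4, 3.2 percentage points apart, within the scatter of two such steps. The methyl in place of phenyl on the amide-type nitrogen, previously seen in a single pair, now recurs on the chlorinated scaffold as a number 20 percentage points lower from compound 3 to compound 4 (beyond the scatter), and the loss is reproduced: the same change on two cores in this assay, a number 16.8 percentage points lower (beyond the scatter) from compound 1 to compound 2 and a number 20 percentage points lower (beyond the scatter) from compound 3 to compound 4, 3.2 percentage points apart, within the scatter of two such steps. Across these four compounds, the two changes therefore appear to act independently, with the group on the amide-type nitrogen separating the values beyond the scatter and the 4-chlorophenyl group leaving the size of that step unchanged within the scatter.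

The compounds shown cover only hydrogen and chloro on this aromatic carbon and only phenyl and methyl on the nitrogen, so the effect of a methoxy or nitro group at that carbon, or of a longer chain such as butyl on the nitrogen, remains open. Going by these compounds, because each value comes from one dose, potency also remains open.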